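Moving the Chlorine Around the Phenyl Ring

The source may hold more compounds than are shown below. What is called first, only, known or untested is meant among the compounds shown, and "the series" means these compounds.

Compound 1, `CCC(C(=O)N1CCN(c2ccccc2Cl)CC1)N1C(=O)CCC1=O`, was tested in a functional assay on the whole organism (strain Swiss) with Mus musculus as the target, in the maximal electroshock model, with a stated time of 1 h, at a dose of 300 mg/kg by the intraperitoneal route (on this read-out lower numbers stand for a weaker effect and higher numbers for a stronger effect at the one dose given), where compound 1 gives 50%. Among the measured compounds shown here, that is the higher of the two numbers measured so far. Its only measured partner, compound 2, `CC(C(=O)N1CCN(c2ccccc2Cl)CC1)N1C(=O)CCC1=O`, gives 25%. For the measured compounds named here, the single measured step, a number 25 percentage points lower from compound 1 to compound 2 (beyond the scatter), came from hydrogen in place of methyl on a saturated chain carbon, not from any change to the aromatic ring.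

Compound 3, `CCC(C(=O)N1CCN(c2cccc(Cl)c2)CC1)N1C(=O)CCC1=O`, has not yet been measured. It differs from compound 1 at the other end of the molecule: 3-chlorophenyl in place of 2-chlorophenyl on an amine nitrogen in a ring. The two have the same atoms, joined differently: the 2-chlorophenyl leaves and a 3-chlorophenyl enters on the amine nitrogen in the ring.

Going by the values given here, no measured step bears on this change; the only step available, between compound 1 and compound 2, touched a saturated chain carbon and tells nothing about where the chlorine sits on the phenyl. Hence no direction can be read off. Compound 3 is therefore expected to land near compound 1, with the step of no change at the digits printed from compound 1 to compound 3 (within the scatter) expected to stay within the scatter, though the uncertainty is wide. The estimate for compound 3 is 50%, expected between 20% and 80%.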

Compound 3, a percentage reported as activity, at one dose (the size of the read-out at that dose, not a potency): 100%
Compound 3: the middle estimate sits 50 percentage points below what was measured; the measured number lies above the stated range.
By their numbers in this assay, from the lowest: compound 2; then compound 1; then compound 3.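

Compound 1 and compound 3 have the same atoms and the same counts of hydrogen-bond donors and acceptors, so the only difference between them is where the chlorine sits on the phenyl group, yet in this assay the change from 2-chlorophenyl to 3-chlorophenyl gives a number 50 percentage points higher from compound 1 to compound 3 (beyond the scatter) at the one dose tested. Among the compounds shown here, the earlier comparison, a number 25 percentage points lower from compound 1 to compound 2 (beyond the scatter), concerned only the saturated chain carbon, so this is the first sign that the aromatic end of the molecule also affects the read-out, and that moving one atom's position there can matter as much as changing the whole group would be expected to. No measurement available here explains why the 3-chlorophenyl compound gives the higher number.

The compounds shown leave open whether the chlorine is needed at all, since a plain phenyl group or a bromine in place of the chlorine would be the direct test. They also leave open whether the chain step seen with 2-chlorophenyl holds with 3-chlorophenyl, which would need hydrogen in place of methyl on the chain of compound 3.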